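A Chain Change Read Against Two Measured Steps

A few compounds are considered here, and "the series" means these few. Any claim that something is new, unique, unknown or untested is made for them only; others in the source may bear on it.

In a functional assay on SKBR cells (Homo sapiens) for cytotoxicity, read by resazurin assay, with a stated time of 72 h (a higher number here means a weaker inhibitor, a lower number a stronger inhibitor), compound 3 (`COc1cc(/C=C/C(=O)OCCCO[N+](=O)[O-])ccc1O`) gives 17200 nM. Compound 1 (`COc1cc(/C=C/C(=O)OCCCCCCO[N+](=O)[O-])ccc1O`) gives 15200 nM, and these two values lie within the scatter of each other. Compound 2 (`COc1cc(/C=C/C(=O)OCCCO[N+](=O)[O-])ccc1OCCCO[N+](=O)[O-]`) is reported only as a limit, > 50000 nM.

The next compound to be read is compound 4 (`COc1cc(/C=C/C(=O)OC/C=C/CO[N+](=O)[O-])ccc1O`). Its structure differs from that of compound 3 by a group of 7 heavy atoms (3 carbon, 1 nitrogen, 3 oxygen; no ring) in place of a group of 6 heavy atoms (2 carbon, 1 nitrogen, 3 oxygen; no ring), on a saturated chain carbon bound to an oxygen next to a carbonyl group, on a saturated chain carbon bound to an oxygen next to a carbonyl group. The closest measured step is a 1.1-fold higher number from compound 1 to compound 3 (0.05 log units; within the scatter), which was also made on a saturated chain carbon, and it supports the expectation of little change. The other measured step, an at least 2.9-fold lower number from compound 2 to compound 3 (0.46 log units; beyond the scatter), was made on an oxygen on an aromatic ring, a place that stays the same in compound 4, so it bears on this change only weakly.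

On this evidence, no shift beyond the scatter is expected in this assay. The expected step is a 1.1-fold lower number from compound 3 to compound 4 (0.06 log units; within the scatter), with no clear direction. For compound 4 the estimated value is 15000 nM, with an expected range of 6500 nM to 35000 nM.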

Compound 4, half-maximal inhibitory concentration: 6530 nM
Compound 4: middle estimate off by 2.3-fold (0.36 log units), on the high side; measured number inside the range.
By their numbers in this assay, from the lowest: compound 4; then compounds 1 and 3 (each within the scatter of the next). At a limit, above all of these: compound 2.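

In this assay the place on a saturated chain carbon bound to an oxygen next to a carbonyl group proves able to move the number, since putting the group of 7 heavy atoms, with its second double bond outside aromatic rings, in place of 2-(nitrooxy)ethyl gives a 2.6-fold lower number from compound 3 to compound 4 (0.42 log units; beyond the scatter) and so a step beyond the scatter. The earlier chain change, a 1.1-fold higher number from compound 1 to compound 3 (0.05 log units; within the scatter) in a step within the scatter, had suggested a chain that tolerates alteration without effect, and the new step shows that this holds for that one change and not for every change along the chain. Nothing measured here speaks to why this step occurs.

The compounds shown do not separate the double bond from the added carbon, so it stays open which of the two goes with the lower number, and whether a longer chain carrying a double bond would read the same way. Going by these compounds, every chain here ends in nitrooxy, so how a chain ending in a carboxylic acid or an amine would read in this assay also remains open.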